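The source may hold more compounds than are shown below. What is called first, only, known or untested is meant among the compounds shown, and "the series" means these compounds.

Compound 2 `O=C1/C(=C/c2ccc(Cl)cc2)CCC/C1=C\c1ccc([N+](=O)[O-])cc1` gives 4100 nM in a functional assay on HL-60 cells (Homo sapiens) for cytotoxicity (on this read-out higher numbers stand for lower toxicity in this test and lower numbers for higher toxicity in this test), the higher of the two numbers recorded, with compound 1 `COc1cc(/C=C2\CCC/C(=C\c3ccc([N+](=O)[O-])cc3)C2=O)ccc1O` beside it at 3400 nM; the two lie within the scatter of each other. Compound 3 `COc1ccc(/C=C2\CCC/C(=C\c3ccc([N+](=O)[O-])cc3)C2=O)cc1` differs from compound 2 by methoxy in place of chloro on an aromatic carbon. Within the data shown here, the only step that bears on this change is the swap on the same aromatic ring: a 1.2-fold higher number from compound 1 to compound 2 (0.08 log units; within the scatter). Because that step a 1.2-fold higher number from compound 1 to compound 2 (0.08 log units; within the scatter) stayed within the scatter, no step beyond the scatter is expected here either, so compound 3 is expected to show a 1.0-fold lower number from compound 2 to compound 3 (0.01 log units; within the scatter), giving an estimate of 4000 nM in this assay, with a range from 1500 nM to 11000 nM.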

Compound 3, half-maximal cytotoxic concentration: > 400000 nM
Compound 3: a limit, no number; the forecaster's own chance of this, stated with the estimate: 10%; middle value at least 100-fold (2.00 log units) away from the limit.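

Compound 3 reads as a limit of the assay, not a number: the limit of > 400000 nM in this assay, at which 1 of the 3 values shown sits. In this assay, methoxy in place of chloro gives an at least 97-fold higher number from compound 2 to compound 3 (1.98 log units; beyond the scatter), and 4-methoxyphenyl in place of 4-hydroxy-3-methoxyphenyl gives an at least 110-fold higher number from compound 1 to compound 3 (2.07 log units; beyond the scatter). So this aromatic carbon, where the earlier swap stayed within the scatter, can carry a large change in the number, and the outcome depends on which group sits there.

Still open, as far as these compounds go, is how compound 1, which also carries a methoxy group, stays within the scatter of compound 2. Equally open, from the compounds shown here alone, is where an amine or a longer ethoxy chain on this carbon would fall.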